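Phenyl Returns in Place of Pyridinyl: Estimating Compound 3

The source may hold more compounds than are shown below. What is called first, only, known or untested is meant among the compounds shown, and "the series" means these compounds.

Measured so far in an in vitro functional assay on Sf9 cells for antagonist activity at histamine H2 receptor (Homo sapiens); on this read-out higher numbers stand for higher potency (the scale is a negative logarithm) and lower numbers for lower potency:
- compound 1, `N#C/N=C(\NCCCCc1ccccc1)NCCCCc1c[nH]cn1`: 5.03
- compound 2, `N#C/N=C(/NCCCCc1c[nH]cn1)NCCCc1cccnc1`: 5.92

For the measured compounds named here, on these two numbers compound 2 stands highest; its only neighbour is compound 1, and the step between them, a number 0.89 log units higher from compound 1 to compound 2 (beyond the scatter), is modest yet beyond the scatter. Compound 3, `CC(CCN/C(=N\C#N)NCCCCc1c[nH]cn1)c1ccccc1`, has not yet been measured in this assay. It differs from compound 2 by 1-phenylethyl in place of (pyridin-3-yl)methyl on a saturated chain carbon, two bonds along the chain from an amine nitrogen.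

Going by the values given here, the one measured step that bears on this change is a number 0.89 log units higher from compound 1 to compound 2 (beyond the scatter), in which a pyridin-3-yl group took the place of benzyl and the number rose. Among the compounds with values here, compound 3 goes the other way, bringing back a carbon-only aromatic ring, though now as 1-phenylethyl and on a saturated chain carbon two bonds along the chain from an amine nitrogen, so no measured pair matches it exactly. A downward step of roughly the size seen before is therefore expected, estimated as a number 0.72 log units lower from compound 2 to compound 3 (beyond the scatter). For compound 3 the expected value in this assay is 5.2, with a range from 4.6 to 5.8.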

Compound 3, negative logarithm of the antagonist equilibrium constant: < 5
Compound 3 ended at the assay's limit; the forecaster's own chance of this, stated with the estimate: 5%; middle value at least 0.20 log units away from the limit.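

In this assay compound 3 gives < 5, which is a limit of the assay and not a number. Even so, placing 1-phenylethyl where (pyridin-3-yl)methyl stood, on a saturated chain carbon, two bonds along the chain from an amine nitrogen, gives a number at least 0.92 log units lower from compound 2 to compound 3 (beyond the scatter), so both compounds with a carbon-only ring now sit clearly under compound 2, and no compound shown goes against this. The comparison with the other carbon-only compound gives a number at least 0.03 log units lower from compound 1 to compound 3 (that floor lies within the scatter), so having 1-phenylethyl in place of phenethyl cannot be told apart from no change, and the true size of both steps stays unread because the reading stops at a limit: the limit of < 5 in this assay, at which 1 of the 3 values shown sits.

The swap from compound 2 to compound 3 alters the ring and the carbon count at once, so the compounds shown cannot say which of the two matters more. A plain benzyl group at this place would separate those two changes, and a pyridin-4-ylmethyl group would show whether the ring nitrogen must sit where it does in compound 2.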